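Exchanging the Arylidene Group in a Thiazolidinone Series

The compounds below may be only part of what the source reports. "The series", "measured", "known", "first", "only" and "open" are said of these compounds alone.

Measured compounds:
compound 1 `O=C1CS/C(=N\c2csc(-c3ccc(Cl)cc3)c2)N1c1ccccc1` — "not determined" (no result reported) in a functional assay on SW-620 cells (Homo sapiens) for cytotoxicity, read by MTT assay, with a stated time of 72 h; a lower number here means a stronger inhibitor, a higher number a weaker inhibitor
compound 2 `Cc1ccc(/C=C2\S/C(=N\c3nc(-c4ccc(Cl)cc4)cs3)NC2=O)cc1` — 890 nM

Among the compounds with values here, compound 1 carries no number in this assay, so compound 2 stands alone as the only compound with a measured value: in this assay compound 2 gives 890 nM. Compound 3 `O=C1N/C(=N/c2nc(-c3ccc(Cl)cc3)cs2)S/C1=C\c1ccc2ccccc2c1` is not yet measured. It differs from compound 2 in one place: naphthalen-2-yl in place of 4-methylphenyl on a double-bonded chain carbon bound to a double-bonded ring carbon. Within the data shown here, with no step between measured compounds to draw on, the size of the change from compound 2 to compound 3 can only be guessed from the structures. A larger aromatic group replaces a smaller one at the same position, and nothing in the data shows how such a swap moves the number; the expected step of a 1.3-fold lower number from compound 2 to compound 3 (0.10 log units; within the scatter) is therefore small, if anything slightly toward a stronger inhibitor, and may well lie within the scatter. Compound 3 is estimated at 700 nM, with a range from 250 nM to 2500 nM.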

Compound 3, half-maximal inhibitory concentration: 20300 nM
The estimate for compound 3 lay 29-fold (1.46 log units) below the measured number, outside the stated range (above it).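

In this assay, the position on a double-bonded chain carbon bound to a double-bonded ring carbon proves sensitive to the aromatic group it carries: naphthalen-2-yl in place of 4-methylphenyl gives a 23-fold higher number from compound 2 to compound 3 (1.36 log units; beyond the scatter). Both groups consist of carbon only and neither has a net charge, yet the change still weakens the compound well beyond the usual variation between repeated measurements. No measurement at hand explains this loss.

This single step leaves open whether the loss follows from the second aromatic ring in general or is particular to naphthalen-2-yl. On these data alone, how a plain phenyl, a 4-methoxyphenyl or a phenyl bearing a carboxylic acid would behave at this place also remains unknown.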